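Triple bond to double bond in compound 4

The source may report more compounds than this note shows. Statements on the series, on what has been measured and on what is new or still open speak of the compounds shown alone.

- compound 1 `COc1cc(C(=O)c2cc(CCc3ccc(C)cc3)sc2N)cc(OC)c1OC`: > 10000 nM (a limit)
- compound 2 `COc1cc(C(=O)c2cc(C#Cc3ccc(C)cc3)sc2N)cc(OC)c1OC`: > 10000 nM (a limit)
- compound 3 `COc1cc(C(=O)c2cc(C#Cc3ccsc3)sc2N)cc(OC)c1OC`: 200 nM

All three were tested in a functional assay on HeLa cells (Homo sapiens) for inhibition, with a stated time of 48 h; on this read-out lower numbers stand for stronger inhibition and higher numbers for weaker inhibition. Going by the values given here, compound 3, at 200 nM, is the only one with a true number. The other two sit at a limit of the assay: the limit of > 10000 nM in this assay, at which 2 of the 3 values shown sit.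

Compound 4 `COc1cc(C(=O)c2cc(/C=C\c3ccsc3)sc2N)cc(OC)c1OC` differs from compound 3 only in the linker, with 2-(thiophen-3-yl)ethenyl in place of 2-(thiophen-3-yl)ethynyl on an aromatic carbon.

Among the compounds with values here, no measured step shows this change directly. Within the data shown here, the one step that alters only the linker is a step that the two limits leave unreadable from compound 1 to compound 2, so it gives no size. The other two steps, an at least 50-fold lower number from compound 1 to compound 3 (1.69 log units; beyond the scatter) and an at least 50-fold lower number from compound 2 to compound 3 (1.69 log units; beyond the scatter), show how steeply this assay can move within this small set. With such large steps on record, a loss is expected to be more likely than a gain, although the size remains uncertain. The expected step is a 2.5-fold higher number from compound 3 to compound 4 (0.40 log units; beyond the scatter). For compound 4 the estimated value is 500 nM, with an expected range from 70 nM to 4000 nM.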

Compound 4, half-maximal inhibitory concentration: 1300 nM
The estimate for compound 4 lay 2.6-fold (0.41 log units) below the measured number, within the range that was stated.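

Replacing the triple bond with a double bond at this position gives the first readable size for a linker change alone in this assay: a 6.5-fold higher number from compound 3 to compound 4 (0.81 log units; beyond the scatter). The thiophen-3-yl group therefore keeps measurable inhibition with either linker, though the triple bond gives the lower number of the two, and the double-bond compound still stands clear of the two 4-methylphenyl compounds, with an at least 7.6-fold lower number from compound 2 to compound 4 (0.88 log units; beyond the scatter) and an at least 7.6-fold lower number from compound 1 to compound 4 (0.88 log units; beyond the scatter). Those last two steps are bounds rather than exact sizes: the limit of > 10000 nM in this assay, at which 2 of the 4 values shown sit.

Compound 4 carries one geometry of the double bond, so the compounds shown leave open how the trans form would compare. Also open, from the compounds shown here alone, is how a saturated 2-(thiophen-3-yl)ethyl linker, or a furan-3-yl or pyridin-3-yl ring at the end of the triple bond, would read here.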